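Methoxy removal on the aryl ring of a triazole-thioacetamide series

A few compounds are considered here, and "the series" means these few. Any claim that something is new, unique, unknown or untested is made for them only; others in the source may bear on it.

Measured compounds:
- compound 1, `CCn1c(SCC(=O)Nc2ccc(/C(C)=N/O)cc2)nnc1-c1ccc(OC)cc1`: 73%
- compound 2, `C=CCn1c(SCC(=O)Nc2ccc(/C(C)=N/O)cc2)nnc1-c1ccc(OC)c(OC)c1`: 79%
- compound 3, `C=CCn1c(SCC(=O)Nc2ccc(/C(C)=N/O)cc2)nnc1-c1cc(OC)c(OC)c(OC)c1`: 72%

All three were run in a functional assay on the whole organism (strain albino) for inhibition, with Rattus norvegicus as the target, read by paw edema, with stated times of 30 min and 4 h, at a dose of 0.28 mmol/kg by the oral route; on this read-out lower numbers stand for less inhibition and higher numbers for more inhibition at the one dose given (going by the name of the read-out). In this assay compound 1 gives 73%, compound 2 gives 79% and compound 3 gives 72%; every gap among the three lies within the usual scatter of the read-out, so the set reads as flat.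

One structural change is documented twice. Between compound 3 and compound 2 it is hydrogen in place of methoxy on an aromatic carbon, and the step it made was a number 7 percentage points higher from compound 3 to compound 2 (within the scatter). The same kind of change leads from compound 1 to the unmeasured compound 4, `CCn1c(SCC(=O)Nc2ccc(/C(C)=N/O)cc2)nnc1-c1ccccc1`: hydrogen in place of methoxy on an aromatic carbon. The two changes are of the same kind but not the same: in compound 3 the leaving methoxy sits ortho to a methoxy group, meta to a large group and meta to a methoxy group, whereas in compound 1 it sits para to a large group. How the cores of compound 1 and compound 3 differ is not broken down here.

Given that the one documented instance of this change stayed within the scatter, and that the whole measured set spans only a narrow band, the step from compound 1 to compound 4 is expected to be small as well: a number 3 percentage points lower from compound 1 to compound 4 (within the scatter), resting on a number 7 percentage points higher from compound 3 to compound 2 (within the scatter) and on the value of compound 1, 73%. Compound 4 is therefore estimated at 70% in this assay, most plausibly between 55% and 82%.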

Compound 4, a percentage reported as inhibition, in the whole organism at one dose (the size of the read-out at that dose, not a potency): 77%
Compound 4: the middle estimate sits 7 percentage points below what was measured, within the range that was stated.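

Hydrogen in place of methoxy on an aromatic carbon, read in this assay, gives a number 4 percentage points higher from compound 1 to compound 4 (within the scatter), and this step can be set beside the earlier one on the other core: the same change on two cores in this assay, a number 7 percentage points higher (within the scatter) from compound 3 to compound 2 and a number 4 percentage points higher (within the scatter) from compound 1 to compound 4, 3 percentage points apart, within the scatter of two such steps. Among these compounds, in these two instances the change therefore carries from one core to the other without a difference that can be told from the scatter, and neither step can be told from no step at all. This does not show that methoxy removal is without consequence in general or that either step has a real direction, since the evidence is two pairs at one dose, with the methoxy leaving from different surroundings on the two cores, and a percentage at one dose is not a potency.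

The compounds shown leave open how this read-out would respond to an amine or a carboxylic acid in place of the methoxy of compound 1, where a larger step might or might not appear. They also leave open whether the same flat picture would hold with a longer chain in place of the ethyl group of compound 1.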